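This account rests on a few compounds, and the source may have more. Where it says the series, first, only, none or still open, it means among the compounds named here.

Compound 1, `O=C(C1CCCCC1)N1CC(c2nc(-c3cccc(F)c3)no2)C1`, carries a cyclohexyl on the carbonyl carbon of the shared core. In an assay on HEK293 cells for positive allosteric modulation of metabotropic glutamate receptor 5 (Homo sapiens), read by FLIPR (on this read-out lower numbers stand for an effect already at smaller amounts and higher numbers for an effect only at larger amounts of compound), compound 1 gives 1000 nM, the highest of the two numbers recorded in this assay. Its nearest neighbour is compound 2, `O=C(N1CCCCC1)N1CC(c2nc(-c3cccc(Cl)c3)no2)C1`, which in this assay gives 370 nM, a lower number by a step beyond the scatter. Compound 3, `O=C(C1CCCO1)N1CC(c2nc(-c3cccc(Cl)c3)no2)C1`, reaches only a limit of this assay, reported as > 10000 nM; that limit is the limit of > 10000 nM in this assay, at which 1 of the 3 values shown sits. Going by the values given here, the single measured step, an at least 27-fold higher number from compound 2 to compound 3 (1.43 log units; beyond the scatter), is large, and it concerns the group on the carbonyl carbon, the same position that is varied here.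

Compound 4, `O=C(c1ccc(F)c(F)c1)N1CC(c2nc(-c3cccc(F)c3)no2)C1`, differs from compound 1 in one place: 3,4-difluorophenyl in place of cyclohexyl on a carbonyl carbon. Among the compounds with values here, no measured step covers a swap of cyclohexyl for an aromatic ring, so the expectation rests only on the fact that the group on the carbonyl carbon can move the number a great deal, as the step from compound 2 to compound 3 showed. An aromatic ring replacing a saturated one is expected to change the number only modestly, so the estimated step of a 1.7-fold lower number from compound 1 to compound 4 (0.22 log units; within the scatter) is small. Compound 4 is therefore expected to give about 600 nM in this assay, within a range of 150 nM to 4000 nM.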

Compound 4, half-maximal effective concentration: 3200 nM
Compound 4: middle estimate off by 5.3-fold (0.73 log units), on the low side; the measured number falls inside the stated range.
By their numbers in this assay, from the lowest: compound 2; then compound 1; then compound 4. At a limit, above all of these: compound 3.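

In this assay, the swap of cyclohexyl for 3,4-difluorophenyl on a carbonyl carbon gives a 3.2-fold higher number from compound 1 to compound 4 (0.51 log units; beyond the scatter), which shows that this position also responds when an aromatic ring enters, and not only in the exchange of piperidin-1-yl for oxolan-2-yl seen earlier. Unlike that earlier step, which ended at a limit of the assay, this one has a measured number at both ends, and its size is modest. The leaving and entering groups both count no hydrogen-bond donors, no hydrogen-bond acceptors and no net charge, so the number moved with those counts unchanged, and nothing measured here accounts for the step.

Going by these compounds, it remains open whether the higher number goes with the aromatic ring itself or with its two fluorine atoms, a question that a plain phenyl on the carbonyl carbon would help to separate. Also open, on these data alone, is how this position would respond to a ring carrying nitrogen, such as a pyridine, or to an open-chain group such as tert-butyl, with the rest of compound 1 kept unchanged.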